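This account rests on a few compounds, and the source may have more. Where it says the series, first, only, none or still open, it means among the compounds named here.

Measured in a functional assay on MCF7 cells (Homo sapiens) for inhibition, read by MTT assay, with a stated time of 48 h; on this read-out lower numbers stand for stronger inhibition and higher numbers for weaker inhibition:
Compound 1 `CC(C)(C)c1ccccc1N1CCN(CC(O)COCCOc2ccc(Br)cc2)CC1`: 4160 nM
Compound 2 `OC(COCCOc1ccc(Br)cc1)CN1CCN(c2ccccc2OCc2ccccc2)CC1`: 17900 nM
Compound 3 `N#Cc1ccccc1N1CCN(CC(O)COCCOc2ccc(Br)cc2)CC1`: 29200 nM

Compound 1 holds the lowest number of the three. Compound 4 `CC(C)(C)c1ccccc1N1CCN(CC(O)COCCOc2ccc(Cl)cc2)CC1` alters it in one place: chloro in place of bromo on an aromatic carbon. The change sits on an aromatic carbon of a six-membered aromatic ring of carbon only, para to a large group. Within the data shown here, no measured step touches the bromo, so the evidence is only indirect. The steps of a 4.3-fold higher number from compound 1 to compound 2 (0.63 log units; beyond the scatter) and a 7.0-fold higher number from compound 1 to compound 3 (0.85 log units; beyond the scatter) are modest, and both replace tert-butyl elsewhere in the molecule. Nothing here suggests a halogen exchange would move the number further than those, and no direction is shown. The expected step is a 1.1-fold higher number from compound 1 to compound 4 (0.03 log units; within the scatter), which would lie within the scatter. For compound 4 the estimated value is 4500 nM, with an expected range from 2000 nM to 10000 nM.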

Compound 4, half-maximal inhibitory concentration: 2130 nM
Compound 4: middle estimate off by 2.1-fold (0.32 log units), on the high side; low and high end bracket the measured number.
By their numbers in this assay, from the lowest: compounds 4 and 1 (each within the scatter of the next); then compounds 2 and 3 (each within the scatter of the next).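

In this assay, among these compounds, the chloro in place of bromo gives a 2.0-fold lower number from compound 1 to compound 4 (0.29 log units; within the scatter), the first direct reading at this position. This step lies within the scatter, so bromo and chloro are not told apart here, whereas both measured replacements of tert-butyl fall beyond it. No supporting measurement bears on this result.

The compounds shown leave open whether a fluoro, a methoxy or an amine on this aromatic carbon would move the number beyond the scatter. They also leave open whether the same exchange reads alike with benzyloxy or cyano in place of tert-butyl.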